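One Group Exchanged on Compound 2

This account rests on a few compounds, and the source may have more. Where it says the series, first, only, none or still open, it means among the compounds named here.

In a functional assay on SH-SY5Y cells (Homo sapiens) for cytotoxicity, read by MTT assay, with a stated time of 72 h (on this read-out lower numbers stand for stronger inhibition and higher numbers for weaker inhibition), compound 2 `CC1(C)OCC(Cn2cc(Cn3c4c(c5ccccc53)C(=O)c3c[n+]([O-])c5ccccc5c3C4=O)nn2)O1` gives 230 nM. Compound 1 `CN(C)CCCCCn1c2c(c3ccccc31)C(=O)c1c[n+]([O-])c3ccccc3c1C2=O` gives 370 nM, which lies within the scatter of that value. Compound 3 `O=C1c2c[n+]([O-])c3ccccc3c2C(=O)c2c1c1ccccc1n2CCCCN1CCNCC1` gives 1240 nM, a higher number than the other two, beyond the scatter of both.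

The next compound is compound 4 `O=C1c2c[n+]([O-])c3ccccc3c2C(=O)c2c1c1ccccc1n2Cc1cn([C@H]2C[C@H](O)[C@@H](CO)O2)nn1`, with this difference: 4-hydroxy-5-(hydroxymethyl)oxolan-2-yl in place of (2,2-dimethyl-1,3-dioxolan-4-yl)methyl on an aromatic nitrogen. It carries 4-hydroxy-5-(hydroxymethyl)oxolan-2-yl in place of (2,2-dimethyl-1,3-dioxolan-4-yl)methyl on an aromatic nitrogen.

Among the measured compounds shown here, no measured step touches this place. The only one available, a 3.4-fold higher number from compound 1 to compound 3 (0.53 log units; beyond the scatter), is a modest step at a different place, so it offers only a rough sense of scale. On the strength of that step, a change no larger is expected in this assay, perhaps towards a higher number, though the data do not settle the direction. The expected step is a 1.5-fold higher number from compound 2 to compound 4 (0.18 log units; within the scatter). For compound 4 the estimated value is 350 nM, with an expected range from 120 nM to 1000 nM.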

Compound 4, half-maximal inhibitory concentration: 620 nM
The estimate for compound 4 lay 1.8-fold (0.25 log units) below the measured number, and the stated range covers the measured number.
By their numbers in this assay, from the lowest: compounds 2, 1, 4 and 3 (each within the scatter of the next, the first and the last beyond it).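

In this assay, the change on an aromatic nitrogen of the five-membered aromatic ring with 3 nitrogen gives a 2.7-fold higher number from compound 2 to compound 4 (0.43 log units; beyond the scatter), the first measured sign that the number responds to the group at this position. The exchange keeps the heavy-atom count and the single five-membered non-aromatic ring, but 4-hydroxy-5-(hydroxymethyl)oxolan-2-yl brings hydrogen-bond donors and defined stereocentres that (2,2-dimethyl-1,3-dioxolan-4-yl)methyl does not have. No measurement available here accounts for the step.

A single pair cannot separate the contributions of the hydroxy groups, the ring and the stereocentres. On these data alone, it also remains open how the number would shift with a simple amine or a carboxylic acid on this aromatic nitrogen, or with the hydroxy groups of the entering group replaced by methoxy groups.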